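Cyclopentyl to cyclobutylmethyl on the aryl ether oxygen

This account rests on a few compounds, and the source may have more. Where it says the series, first, only, none or still open, it means among the compounds named here.

Measured so far:
compound 1, `CNc1nc(OC2CCCC2)nc2c1ncn2Cc1c(F)cccc1F`: 4.3
compound 2, `CN(Cc1ccc2nccn2c1)c1nnc(-c2ccc(OC3CCCC3)cc2)o1`: 4.1

Two compounds have been run in a physicochemical assay for lipophilicity, at pH 7.4; on this read-out lower numbers stand for lower lipophilicity and higher numbers for higher lipophilicity. Compound 1 gives 4.3 and compound 2 gives 4.1; the two numbers lie within the usual scatter of each other, so neither separates from the other on this read-out. Going by the values given here, no pair of measured compounds differs in only one place, so no single-change step is available to lean on.

Compound 3, `CNc1nc(OCC2CCC2)nc2c1ncn2Cc1c(F)cccc1F`, is not yet measured. It differs from compound 1 in one place: cyclobutylmethyl in place of cyclopentyl on an oxygen on an aromatic ring. The same atoms are present in both compounds, only joined differently, and nothing is added or removed in terms of donors, acceptors or charge. With no measured step of this kind in the series, the expectation rests on that equality alone: the step from compound 1 to compound 3 is expected to be no change at the digits printed from compound 1 to compound 3 (within the scatter), that is, no change beyond the scatter in either direction. Compound 3 is therefore expected to give 4.3, with a range of 3.9 to 4.7.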

Compound 3, distribution coefficient: 4.4
Beside the measured number, compound 3's estimate is 0.10 log units below it, and the stated range covers the measured number.
By their numbers in this assay, from the lowest: compounds 2, 1 and 3 (each within the scatter of the next).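

Going by these compounds alone, this is the first single-change step: in this assay, cyclobutylmethyl in place of cyclopentyl on an oxygen on an aromatic ring gives a number 0.10 log units higher from compound 1 to compound 3 (within the scatter). On the core of compound 1, this read-out therefore does not separate the two groups, although one carries a five-membered ring on the oxygen and the other a four-membered ring. The step comes from a single pair on a single core, and no available evidence bears on why the two groups read alike.

Going by these compounds, compound 2 also carries cyclopentyl on an oxygen on an aromatic ring, but on a different core, so it remains open whether the same exchange would also stay within the scatter there. Also open, on these data alone, is how this assay would respond on this oxygen to a group of a different kind, such as a chain ending in an amine or a carboxylic acid, or to a longer chain such as n-hexyl, since both groups in this step are all-carbon with no hydrogen-bond donors or acceptors.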